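The compounds below may be only part of what the source reports. "The series", "measured", "known", "first", "only" and "open" are said of these compounds alone.

In a functional assay on A549 cells (Homo sapiens) for inhibition, read by MTT assay, with a stated time of 24 h (on this read-out higher numbers stand for weaker inhibition and lower numbers for stronger inhibition), compound 1 `CCOC(=O)C1=Cc2ccccc2OC1(OCc1cc(-c2ccc(Br)cc2)no1)C(F)(F)F` gives > 150000 nM, which is a limit of the assay and not a number. Compound 2 `O=C(O)C1=Cc2ccccc2OC1(OCc1cc(-c2ccc(F)cc2F)no1)C(F)(F)F` gives > 150000 nM, again only a limit. Compound 3 `CCOC(=O)C1=Cc2ccccc2OC1(OCc1cn(-c2ccccc2)nn1)C(F)(F)F` likewise reaches no number but the limit > 150000 nM. On the numbers shown, compound 3 therefore stands exactly where the other two compounds stand, because of the limit of > 150000 nM in this assay, at which 3 of the 3 values shown sit. Compound 4 `CCOC(=O)C1=Cc2ccccc2OC1(OCc1cn(CC(=O)Nc2ccc(OC)cc2)nn1)C(F)(F)F` differs from compound 3 by ((4-methoxyphenyl)carbamoyl)methyl in place of phenyl on an aromatic nitrogen. Among the compounds with values here, with no measured step available between any two compounds, the step from compound 3 to compound 4 is expected to be a step that the limit leaves unreadable from compound 3 to compound 4, none beyond the scatter. Compound 4 is thus expected to give 200000 nM in this assay, estimated between 80000 nM and 600000 nM, most likely once more reported only as a limit.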

Compound 4, half-maximal inhibitory concentration: 29400 nM
Compound 4: the middle estimate sits 6.8-fold (0.83 log units) above what was measured; measured number outside the range, below it.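

In this assay, the aromatic nitrogen of the five-membered aromatic ring proves to be a place where a change moves the read-out: ((4-methoxyphenyl)carbamoyl)methyl in place of phenyl gives an at least 5.1-fold lower number from compound 3 to compound 4 (0.70 log units; beyond the scatter). Compound 4 is the only compound shown that yields a number rather than a limit. The true size of the step stays unknown because compound 3 has only a limit: the limit of > 150000 nM in this assay, at which 3 of the 4 values shown sit.

The compounds shown do not tell whether the amide, the methoxy group or the added methylene carries this step. Nor do they show how a plain benzyl group, or a chlorine in place of the methoxy group, would read.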